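This account rests on a few compounds, and the source may have more. Where it says the series, first, only, none or still open, it means among the compounds named here.

Compound 1 `N/C(=N\NC(=S)N1CCCCCC1)c1ccccn1` and compound 2 `N/C(=N\NC(=S)N1CCCCC1)c1ccccn1` share most of their structure; how the two cores differ is not broken down here. In a functional assay on A-431 cells (Homo sapiens) for cytotoxicity, read by MTT assay, with a stated time of 72 h, tested at 3 uM (a lower number here means less inhibition of growth, a higher number more inhibition of growth at the concentration tested), compound 1 gives 50.3%, while compound 2 gives 27%, the lowest reading among the three measured compounds, with both gaps to the others beyond the scatter. Compound 3 `Cc1cccc(/C(N)=N/NC(=S)N2CCCCCC2)n1` arises from compound 1 by a single change, (methyl in place of hydrogen on an aromatic carbon), and in this assay compound 3 gives 44.1%. The resulting step, a number 6.2 percentage points lower from compound 1 to compound 3 (within the scatter), is small.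

Compound 4 `Cc1ccnc(/C(N)=N/NC(=S)N2CCCCC2)c1` has not yet been measured. It stands to compound 2 as compound 3 stands to compound 1, the change being (methyl in place of hydrogen on an aromatic carbon). This is the same kind of change, but not the same one: in compound 3 the methyl sits next to the ring nitrogen and meta to a large group, whereas in compound 4 it sits meta to a large group and opposite the ring nitrogen. Among these compounds the change occurs twice, once with a measured outcome.

The expectation rests on compound 1 and compound 3, whose step a number 6.2 percentage points lower from compound 1 to compound 3 (within the scatter) stayed within the scatter. A step of about the same small size is expected here, namely a number 2 percentage points lower from compound 2 to compound 4 (within the scatter) in this assay. Compound 4 is therefore estimated to give 25% in this assay, with a likely range from 10% to 42%.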

Compound 4, percent growth inhibition at one concentration: 36.5%
Compound 4: middle estimate off by 11.5 percentage points, on the low side; measured number inside the range.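

In this assay, methyl in place of hydrogen opposite the ring nitrogen on the core of compound 2 gives a number 9.5 percentage points higher from compound 2 to compound 4 (within the scatter), and this step does not match the earlier one on the core of compound 1: the same change on two cores in this assay, a number 6.2 percentage points lower (within the scatter) from compound 1 to compound 3 and a number 9.5 percentage points higher (within the scatter) from compound 2 to compound 4, 15.7 percentage points apart, beyond the scatter of two such steps. Each step taken alone stays within the scatter, but together they show that this change does not carry from one core to the other as a single fixed step. They do not show what lies behind the mismatch, since the two pairs differ both in the core and in where the methyl sits on the aromatic ring, and with one pair of each kind these two differences cannot be told apart.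

The compounds shown leave open whether a methyl in the place it has in compound 3 would give a similar step on the core of compound 2, and whether a methyl in the place it has in compound 4 would do so on the core of compound 1. They also leave open what an ethyl group, a methoxy group or an amine would do on these same ring carbons.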